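Halogen Swap on a Benzyl Thioether: Expecting Compound 4

The source may hold more compounds than are shown below. What is called first, only, known or untested is meant among the compounds shown, and "the series" means these compounds.

Three compounds have been measured in a functional assay on SW 1116 cells (Homo sapiens) for antiproliferative activity, read by MTT assay, with a stated time of 48 h; a higher number here means a weaker inhibitor, a lower number a stronger inhibitor:

Compound 1, `Clc1cccc(CSc2nnc(-c3cnccn3)n2-c2ccccc2)c1`: 6610 nM
Compound 2, `Brc1cccc(CSc2nnc(-c3cnccn3)n2-c2ccccc2)c1`: 5030 nM
Compound 3, `Clc1ccc(CSc2nnc(-c3cnccn3)n2-c2ccccc2)cc1`: 12500 nM

Compound 1 and compound 2 share one core and differ only by bromo in place of chloro on an aromatic carbon. That swap gave a 1.3-fold lower number from compound 1 to compound 2 (0.12 log units; within the scatter), so the two values cannot be told apart. Compound 1 and compound 3 are built from the same atoms joined differently: 4-chlorophenyl in place of 3-chlorophenyl on a saturated chain carbon bound to a sulfur. This rearrangement gave a 1.9-fold higher number from compound 1 to compound 3 (0.28 log units; within the scatter), and from the bromo analogue it gave a 2.5-fold higher number from compound 2 to compound 3 (0.40 log units; beyond the scatter). Compound 3 thus carries the highest number of the three, though its gap to compound 1 stays within the scatter.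

Compound 4, `Brc1ccc(CSc2nnc(-c3cnccn3)n2-c2ccccc2)cc1`, has not yet been measured. It differs from compound 3 by bromo in place of chloro on an aromatic carbon. Among the compounds with values here, this is the same kind of change as the one from compound 1 to compound 2, but not the same: in the earlier pair the halogen sits meta to a large group, whereas in compound 4 it sits para to a large group. Within the data shown here, only one instance of this swap has been measured, and no data show how the para position responds to it. Because the earlier swap gave a 1.3-fold lower number from compound 1 to compound 2 (0.12 log units; within the scatter), a step of similar, small size is expected here, a 1.3-fold lower number from compound 3 to compound 4 (0.12 log units; within the scatter). Compound 4 is therefore estimated to give 9500 nM in this assay. Its expected range is estimated to run from 4500 nM to 20000 nM.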

Compound 4, half-maximal inhibitory concentration: 6210 nM
For compound 4 the middle estimate is 1.5-fold (0.18 log units) above the measured one; low and high end bracket the measured number.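

In this assay, bromo in place of chloro on an aromatic carbon can now be followed on two cores, one with the halogen in the 3-halophenyl arrangement and one with it para to a large group, and the two results cannot be told apart: the same change on two cores in this assay, a 1.3-fold lower number (0.12 log units; within the scatter) from compound 1 to compound 2 and a 2.0-fold lower number (0.30 log units; within the scatter) from compound 3 to compound 4, 1.5-fold (0.19 log units) apart, within the scatter of two such steps. So, in these two pairs, the step carries from one core to the other without a detectable difference, but each step taken alone, including the new one, a 2.0-fold lower number from compound 3 to compound 4 (0.30 log units; within the scatter), stays within the scatter, so neither pair shows that the swap itself changes the number. Compound 4 also cannot be separated from the other bromo or chloro compounds by these data, as shown by a 1.2-fold higher number from compound 2 to compound 4 (0.09 log units; within the scatter) and by a 1.1-fold lower number from compound 1 to compound 4 (0.03 log units; within the scatter), and two pairs are too few to establish a rule for the whole series.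

The compounds shown carry only chloro or bromo on the benzyl group, so it stays open whether a fluoro, methoxy, nitrile or carboxylic acid group there would follow the same trend. On these data alone, it is also open whether the swap would carry over to a core with an amine or a longer chain in place of the present benzyl thioether link.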